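The compounds below may be only part of what the source reports. "The series", "measured", "known", "first", "only" and "open" are said of these compounds alone.

Measured in a functional assay on RD cells (Homo sapiens) for inhibition, read by luminescence and ATP content, with a stated time of 72 h; a higher number here means that more compound is tolerated, a lower number that less compound is tolerated:
Compound 1 `Cc1nc(-c2cnc3ccc(-c4ccc(N)nc4)cc3c2)no1`: > 7400 nM, a limit
Compound 2 `CCCCc1ccc(-c2ccc3ncc(-c4noc(C)n4)cc3c2)cc1`: > 2500 nM, a limit

For the measured compounds named here, neither compound has yet given an actual number in this assay, so no step between them can be read. Compound 2 stands at a limit, > 2500 nM, and that is all that is known of it here. Going by the values given here, the only other result is also a limit, the one for compound 1.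

Compound 3 `CCc1ccc(-c2ccc3ncc(-c4noc(C)n4)cc3c2)cc1` keeps the shared core of compound 2 and differs only in its chain, which goes from butyl to ethyl. This is hydrogen in place of ethyl on a saturated chain carbon, two bonds along the chain from an aromatic carbon. Among the compounds with values here, no measured pair yet shows what such a change does in this assay. The expectation therefore rests on the limit of compound 2, > 2500 nM, and no change beyond the usual scatter is expected. The estimated step that the limit leaves unreadable from compound 2 to compound 3 is expected to be small, and it may well end in another limit. The estimate for compound 3 is 4000 nM, with an expected range of 1800 nM to 10000 nM.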

Compound 3, half-maximal cytotoxic concentration: > 7400 nM
Compound 3: no number, only a limit; the forecaster's own chance of this, stated with the estimate: 75%; middle value at least 1.8-fold (0.26 log units) from the limit.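

In this assay compound 3 gives > 7400 nM, a limit and not a number. The steps from compound 2 and from compound 1 to compound 3 each join two limits, so neither can be read. The compounds shown leave open the half-maximal cytotoxic concentration of each, and whether ethyl in place of butyl changes it at all.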